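The compounds below may be only part of what the source reports. "The series", "measured", "known", "first", "only" and "open" are said of these compounds alone.

Three close relatives of one shared core have been measured in a functional assay on MKN-74 cells (Homo sapiens) for antiproliferative activity, with a stated time of 24 h; on this read-out lower numbers stand for stronger inhibition and higher numbers for weaker inhibition. Compound 1 `NC(=O)c1c(NC(=O)c2ccccc2Cl)sc2c1CCN(Cc1ccccc1)C2` gives 14500 nM. Compound 2 `NC(=O)c1c(NC(=O)c2ccccc2Cl)sc2c1CCN(Cc1ccc(Cl)cc1)C2` gives 18700 nM. Compound 3 `NC(=O)c1c(NC(=O)c2ccccc2Cl)sc2c1CCN(Cc1ccc(Cl)cc1Cl)C2` gives 16300 nM, the second highest of the three numbers, although every gap among them lies within the scatter: a 1.3-fold higher number from compound 1 to compound 2 (0.11 log units; within the scatter), a 1.1-fold higher number from compound 1 to compound 3 (0.05 log units; within the scatter) and a 1.1-fold lower number from compound 2 to compound 3 (0.06 log units; within the scatter). Compound 4 `NC(=O)c1c(NC(=O)c2ccccc2Cl)sc2c1CCN(C(=S)Nc1ccccc1I)C2` has not been measured. It differs from compound 3 in that (a group of 10 heavy atoms (7 carbon, 1 nitrogen, 1 sulfur, 1 iodine; one six-membered aromatic ring of carbon only) in place of a group of 9 heavy atoms (7 carbon, 2 chlorine; one six-membered aromatic ring of carbon only), on an amine nitrogen in a ring). The three measured steps all concern the group on this same ring nitrogen, yet each only added chloro to, or removed it from, a benzyl group, and none moved the read-out beyond the scatter. Among the compounds with values here, the change to compound 4 is of another kind, bringing in nitrogen, sulfur, iodine, a double bond outside aromatic rings, and a hydrogen-bond donor and acceptor, so no measured step covers it. With that caution, the expected step in this assay is a 1.1-fold lower number from compound 3 to compound 4 (0.04 log units; within the scatter), within the scatter. Compound 4 is therefore estimated at 15000 nM, with a range from 4500 nM to 50000 nM.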

Compound 4, half-maximal inhibitory concentration: 2630 nM
Estimate against measurement, compound 4: 5.7-fold (0.76 log units) above, outside the stated range (below it).
By their numbers in this assay, from the lowest: compound 4; then compounds 1, 3 and 2 (each within the scatter of the next).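

In this assay, the group on the ring nitrogen turns out to matter: each step away from a benzyl group lies beyond the scatter (a 6.2-fold lower number from compound 3 to compound 4 (0.79 log units; beyond the scatter)) and (a 7.1-fold lower number from compound 2 to compound 4 (0.85 log units; beyond the scatter)) and (a 5.5-fold lower number from compound 1 to compound 4 (0.74 log units; beyond the scatter)). Adding chloro to the benzyl group left the number within the scatter, whereas replacing the whole group does shift it, so this position is not indifferent to what it carries. Nothing shown here gives a measured reason for the lower number.

Compound 4 brings in nitrogen, sulfur and iodine in a single change, so the compounds shown cannot tell which of these goes with the lower number. A close analogue of compound 4 with oxygen in place of sulfur, or with hydrogen or chloro in place of iodine, would separate these parts.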